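The source may hold more compounds than are shown below. What is called first, only, known or untested is meant among the compounds shown, and "the series" means these compounds.

Measured so far in a functional assay on U-251 cells (Homo sapiens) for antiproliferative activity, read by MTT assay, with a stated time of 24 h; a higher number here means a weaker inhibitor, a lower number a stronger inhibitor:

Compound 1, `COc1cc(OC)c(-c2coc3cc(OCc4ccccc4)ccc3c2=O)cc1OC`: 6750 nM
Compound 2, `COc1ccc2c(=O)c(-c3cc(OC)c(OC)cc3OC)coc2c1`: 9400 nM

Compound 2 and compound 1 share the core and differ only at the oxygen on the aromatic ring that carries, in compound 1, a phenyl on a saturated chain carbon. The step of a 1.4-fold higher number from compound 1 to compound 2 (0.14 log units; within the scatter) does not separate the two; on the numbers shown compound 2 stands beside compound 1, with nothing between them beyond the scatter.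

Compound 3, `COc1cccc(C(=O)Oc2ccc3c(=O)c(-c4cc(OC)c(OC)cc4OC)coc3c2)c1`, is not yet measured in this assay. It differs from compound 2 by (3-methoxyphenyl)carbonyl in place of methyl on an oxygen on an aromatic ring, at the same oxygen that was varied between compound 1 and compound 2. That one measured step is the only one that bears on the change here. It was within the scatter, so a group of markedly different size at this oxygen left the number where it was. On that basis no step beyond the scatter is expected from compound 2 to compound 3, and the expected step is a 1.3-fold lower number from compound 2 to compound 3 (0.10 log units; within the scatter).

Compound 3 is therefore estimated at 7500 nM in this assay, with a range from 2500 nM to 22000 nM.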

Compound 3, half-maximal inhibitory concentration: > 10000 nM
Compound 3: no number, only a limit (the forecaster's own chance of this, stated with the estimate: 10%); at least 1.3-fold (0.12 log units) between middle value and limit.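

In this assay compound 3 gives > 10000 nM, which is a limit of the assay and not a number. With (3-methoxyphenyl)carbonyl on this oxygen, the series now has a carbonyl directly on the oxygen on an aromatic ring, and the readings give an at least 1.0-fold higher number from compound 2 to compound 3 (0.02 log units; that floor lies within the scatter) and an at least 1.4-fold higher number from compound 1 to compound 3 (0.17 log units; that floor lies within the scatter), so neither step has a fixed size and both could prove small or large. What is new at this position is that the change gives no sign of a lower number than those of the methyl and benzyl compounds, and its reading has no upper end, unlike the measured step between those two: the limit of > 10000 nM in this assay, at which 1 of the 3 values shown sits.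

The compounds shown leave open whether the carbonyl or the 3-methoxyphenyl ring governs the reading of compound 3, and a plain benzoyl group or an acetyl group on the same oxygen would help to separate the two. On these data alone, how an amine on a longer chain or a carboxylic acid at this oxygen would read also remains open.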